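Swapping a Trihydroxyphenyl Ring for a Methylthiophene on Two Cores

The source may report more compounds than this note shows. Statements on the series, on what has been measured and on what is new or still open speak of the compounds shown alone.

Four related compounds each carry an aromatic ring on a double-bonded chain carbon, and that ring is what changes within each pair. Compound 1 `Cc1ccc(S(=O)(=O)/C(=C/c2ccc(C)s2)C(=O)c2ccc(Br)cc2)cc1` and compound 2 `Cc1ccc(S(=O)(=O)/C(=C/c2c(O)cc(O)cc2O)C(=O)c2ccc(Br)cc2)cc1` share one core; compound 3 `O=C(/C(=C\c1c(O)cc(O)cc1O)SCc1ccc(Cl)cc1)c1ccc(Cl)cc1` and compound 4 `Cc1ccc(/C=C(/SCc2ccc(Cl)cc2)C(=O)c2ccc(Cl)cc2)s1` share another. The difference between the two cores is not broken down here.

Growth inhibition was measured in a functional assay on DU-145 cells (Homo sapiens) for inhibition, read by trypan blue exclusion, with a stated time of 96 h; a lower number here means a stronger inhibitor of growth, a higher number a weaker inhibitor of growth. In this assay compound 1 gives 25000 nM. Compound 2 reaches only the limit of the measurement, > 100000 nM, so no number is known for it. The change from compound 2 to compound 1 is 5-methylthiophen-2-yl in place of 2,4,6-trihydroxyphenyl on a double-bonded chain carbon bound to a double-bonded chain carbon, and it produced an at least 4.0-fold lower number from compound 2 to compound 1 (0.60 log units; beyond the scatter).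

Compound 3 likewise reaches only the limit, > 100000 nM. It therefore sits at the limit of > 100000 nM in this assay, at which 2 of the 3 values shown sit. The change from compound 3 to compound 4 is 5-methylthiophen-2-yl in place of 2,4,6-trihydroxyphenyl on a double-bonded chain carbon bound to a double-bonded chain carbon; this is the same change as the measured one, now made on the other core, and compound 4 has not yet been measured.

On the strength of the measured step of an at least 4.0-fold lower number from compound 2 to compound 1 (0.60 log units; beyond the scatter), a step of about the same size is expected on the second core, an at least 2.5-fold lower number from compound 3 to compound 4 (0.39 log units; beyond the scatter). Compound 4 is accordingly estimated at 40000 nM, most likely falling between 15000 nM and 100000 nM, with a real chance that only a limit is reported again.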

Compound 4, concentration for 50% growth inhibition: 50000 nM
The estimate for compound 4 lay 1.3-fold (0.10 log units) below the measured number; low and high end bracket the measured number.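

Made on the second core, the change from 2,4,6-trihydroxyphenyl to 5-methylthiophen-2-yl gives an at least 2.0-fold lower number from compound 3 to compound 4 (0.30 log units; that floor lies within the scatter) in this assay. Compound 3 has only a limit, > 100000 nM, not a true number, and the real step may be larger than this floor, which on its own lies within the usual scatter. Both steps run the same way, toward a lower number with the methylthiophene, yet this shows only a shared direction on two cores and not that the change is worth the same amount on each: the same change on two cores in this assay, an at least 4.0-fold lower number (0.60 log units; beyond the scatter) from compound 2 to compound 1 and an at least 2.0-fold lower number (0.30 log units; that floor lies within the scatter) from compound 3 to compound 4; the limit leaves it open whether they differ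

The compounds shown leave open how weak the two trihydroxyphenyl compounds really are, and whether the gain comes from losing the hydroxyl groups or from changing the ring itself, as the swap alters both at once. Also open, on these data alone, is how other groups on this double-bonded chain carbon would fare, such as an unsubstituted phenyl ring, a thiophene without the methyl group, or a phenyl ring carrying an amine or a carboxylic acid.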